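The source may report more compounds than this note shows. Statements on the series, on what has been measured and on what is new or still open speak of the compounds shown alone.

Within the data shown here, compound 2 `COc1ccc(-c2cn(CCCN3C(=O)COc4ccccc43)nn2)cc1` gives 41500 nM in a functional assay on MDA-MB-231 cells (Homo sapiens) for antiproliferative activity, read by sulforhodamine B assay, with a stated time of 48 h (a lower number here means a stronger inhibitor of growth, a higher number a weaker inhibitor of growth), and so has the higher of the two numbers measured so far; its nearest neighbour is compound 1 `Cc1ccc(-c2cn(CCCN3C(=O)COc4ccccc43)nn2)cc1`, which gives 1120 nM. Among the measured compounds shown here, the one step available, a 37-fold higher number from compound 1 to compound 2 (1.57 log units; beyond the scatter), concerns methoxy in place of methyl on an aromatic carbon and is beyond the scatter. Compound 3 `O=C1COc2ccccc2N1CCCn1cc(CCCCl)nn1` differs from compound 2 in another way: 3-chloropropyl in place of 4-methoxyphenyl on an aromatic carbon. For the measured compounds named here, no measured pair shows the loss of the 4-methoxyphenyl group or the entry of a 3-chloropropyl chain, so the measured step does not bear directly on this change and the direction is open. Given that compound 2 already gives 41500 nM, compound 3 is expected to show a step of a 1.4-fold higher number from compound 2 to compound 3 (0.16 log units; within the scatter), with wide uncertainty. Compound 3 is therefore estimated at 60000 nM, within a range from 10000 nM to 350000 nM.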

Compound 3, concentration for 50% growth inhibition: 6400 nM
For compound 3 the middle estimate is 9.4-fold (0.97 log units) above the measured one; the measured number lies below the stated range.
By their numbers in this assay, from the lowest: compound 1; then compound 3; then compound 2.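

On the aromatic carbon of the five-membered ring, a ring-free 3-chloropropyl chain can take the place of an aryl group and still keep a number well short of the highest one in this assay. The direction of this change depends on the aryl group it replaces: replacing 4-methoxyphenyl gives a 6.5-fold lower number from compound 2 to compound 3 (0.81 log units; beyond the scatter) and replacing 4-methylphenyl gives a 5.7-fold higher number from compound 1 to compound 3 (0.76 log units; beyond the scatter) in the opposite direction. No measurement at hand explains why these two replacements differ.

As far as these compounds go, what the chlorine contributes apart from the chain remains open. So does how a plain propyl chain, a longer chloroalkyl chain or a chain ending in an amine would compare on this carbon.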